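The compounds below may be only part of what the source reports. "The series", "measured", "known", "first", "only" and "open" are said of these compounds alone.

Compound 1 `CCCn1c(SCc2cc([N+](=O)[O-])ccc2OC)nc2cc(NC(=O)NC(C)(C)C)cc(C(=O)OC)c21`: 280 nM
Compound 2 `CCCn1c(SCc2cc([N+](=O)[O-])ccc2OC)nc2cc(NC(=O)NC(C)(C)C)cc(C(=O)NC)c21`: 23 nM
Compound 3 `CCCn1c(SCc2cc([N+](=O)[O-])ccc2OC)nc2cc(NC(=O)NC(C)(C)C)cc(C(=O)NCc3cccnc3)c21`: 54 nM

In an assay on isolated protein for inhibition of Gonadotropin-releasing hormone receptor (Rattus norvegicus) (a higher number here means a weaker inhibitor, a lower number a stronger inhibitor), compound 3 stands second highest of the three numbers, with compound 2 the lower neighbour and compound 1 the furthest, higher value. The steps already measured all concern the carbonyl substituent of the shared core: a 12-fold lower number from compound 1 to compound 2 (1.09 log units; beyond the scatter), a 5.2-fold lower number from compound 1 to compound 3 (0.71 log units; beyond the scatter), and a 2.3-fold higher number from compound 2 to compound 3 (0.37 log units; beyond the scatter).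

Compound 4 `CCCn1c(SCc2cc([N+](=O)[O-])ccc2OC)nc2cc(NC(=O)NC(C)(C)C)cc(C(=O)NCCCN(C)C)c21` is the next amide in the set. The change is 2-(dimethylamino)ethyl in place of pyridin-3-yl on a saturated chain carbon bound to an amide-type nitrogen. For the measured compounds named here, of the measured steps, the one from compound 2 to compound 3 bears most directly, since it shows what a larger group on the same saturated chain carbon did; the two steps from compound 1 show that the amides as a group sit well below the ester. Going by the values given here, for 2-(dimethylamino)ethyl itself there is no precedent here. The expected step in this assay is therefore small: a 1.2-fold lower number from compound 3 to compound 4 (0.08 log units; within the scatter), within the scatter. Compound 4 is expected to give about 45 nM, within 15 nM to 140 nM.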

Compound 4, half-maximal inhibitory concentration: 19 nM
The estimate for compound 4 lay 2.4-fold (0.37 log units) above the measured number; the measured number falls inside the stated range.
By their numbers in this assay, from the lowest: compounds 4 and 2 (each within the scatter of the next); then compound 3; then compound 1.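

In this assay, the 3-(dimethylamino)propyl chain gives the first clear gain among the substituted amides, with a 2.8-fold lower number from compound 3 to compound 4 (0.45 log units; beyond the scatter) when it replaces the (pyridin-3-yl)methyl group. This place on the amide-type nitrogen therefore accepts a flexible-looking open chain as well as the methyl group of compound 2: a 1.2-fold lower number from compound 2 to compound 4 (0.08 log units; within the scatter) stays within the scatter, while a 15-fold lower number from compound 1 to compound 4 (1.17 log units; beyond the scatter) keeps compound 4 well clear of the ester. No measured evidence accounts for these differences.

The compounds shown do not separate the contribution of the terminal dimethylamino group from that of the chain carrying it, which a plain butyl amide or a morpholine-capped propyl chain would address. From the compounds shown here alone, how far the chain can vary is also open, and a shorter or longer chain ending in the same amine would test this.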